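Swapping cyclohexyl for trifluoroethyl in a stability series

This account rests on a few compounds, and the source may have more. Where it says the series, first, only, none or still open, it means among the compounds named here.

Compound 1 `CCCCN(Cc1ccc(OCCN2C(=O)CCC2=O)c(C)c1)C(CC(=O)O)c1ccc(Cl)cc1`: 88%
Compound 2 `Cc1cc(CN(CC2CCCCC2)C(CC(=O)O)c2ccc(Cl)cc2)ccc1OCCN1C(=O)CCC1=O`: 57%

In an ADME assay on liver (Mus musculus) for metabolic stability, read by LC-MS, using microsomes and NADPH (on this read-out higher numbers stand for a more stable compound and lower numbers for a less stable compound), compound 2 stands lowest of the two at 57%. Compound 3 `Cc1cc(CN(CCC(F)(F)F)C(CC(=O)O)c2ccc(Cl)cc2)ccc1OCCN1C(=O)CCC1=O` has not yet been measured. It carries 2,2,2-trifluoroethyl in place of cyclohexyl on a saturated chain carbon bound to an amine nitrogen. For the measured compounds named here, only one measured step bears on this change, and it sits at the same place: a number 31 percentage points lower from compound 1 to compound 2 (beyond the scatter), where cyclohexyl took the place of propyl. The entering group, like propyl, has no ring, so removing the cyclohexyl may recover much of that large drop. Still, a single pair is thin evidence, and no fluorinated group has been tested yet. A rise beyond the scatter is expected, a number 23 percentage points higher from compound 2 to compound 3 (beyond the scatter). The estimated value for compound 3 is 80%, with an expected range from 60% to 95%.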

Compound 3, percent of the compound remaining: 56%
For compound 3 the middle estimate is 24 percentage points above the measured one; measured number outside the range, below it.
By their numbers in this assay, from the lowest: compounds 3 and 2 (each within the scatter of the next); then compound 1.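

In this assay, the ringless 2,2,2-trifluoroethyl in place of cyclohexyl gives a number 1 percentage points lower from compound 2 to compound 3 (within the scatter), so removing the ring does not by itself restore the number of compound 1. Trifluoromethyl in place of ethyl on a saturated chain carbon, two bonds along the chain from an amine nitrogen, gives a number 32 percentage points lower from compound 1 to compound 3 (beyond the scatter), which shows that an open chain at this position is no guarantee of a high number. Nothing given here explains why these two quite different groups end up within the scatter of each other.

On these data alone, it remains open whether the fall in compound 3 needs all three fluorines or would also appear with a single fluorine at the chain end. A longer unbranched chain, such as pentyl, would show how far the number of compound 1 extends to other plain alkyl chains.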